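A few compounds are considered here, and "the series" means these few. Any claim that something is new, unique, unknown or untested is made for them only; others in the source may bear on it.

Compound 1 `CCc1ccc(NC(=O)c2csc(Cc3c(Cl)cccc3Cl)n2)cc1` is followed in an assay on CHO cells, read by calcium flux (on this read-out higher numbers stand for weaker inhibition and lower numbers for stronger inhibition), where compound 1 gives 810 nM. This is the higher of the two numbers available: compound 3 `O=C(Nc1ccc(C(F)(F)F)nc1)c1csc(Cc2c(Cl)cccc2Cl)n1` gives 110 nM in this assay, a gap beyond the usual scatter. In this assay compound 2 `O=C(Nc1ccccc1)c1csc(Cc2c(Cl)cccc2Cl)n1` gives only > 4000 nM, which is a limit of the assay and not a number. Among the measured compounds shown here, because compound 2 sits at the limit of > 4000 nM in this assay, at which 1 of the 3 values shown sits, the only step measured in a single place, an at least 4.9-fold higher number from compound 1 to compound 2 (0.69 log units; beyond the scatter), is known as a bound only; it comes from hydrogen in place of ethyl on an aromatic carbon.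

Compound 4 `O=C(Nc1ccccc1Br)c1csc(Cc2c(Cl)cccc2Cl)n1` differs from compound 1 by 2-bromophenyl in place of 4-ethylphenyl on an amide-type nitrogen. The step from compound 1 to compound 2 bears on this, since compound 4 also gives up the 4-ethylphenyl, while what the 2-bromophenyl contributes cannot be read from any measured pair here. Compound 4 is therefore expected to give 3000 nM in this assay, between 800 nM and 12000 nM, with a fair chance of a limit. The expected step is a 3.7-fold higher number from compound 1 to compound 4 (0.57 log units; beyond the scatter).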

Compound 4, half-maximal inhibitory concentration: > 4000 nM
Compound 4: only a limit was reported; the forecaster's own chance of this, stated with the estimate: 40%; middle value at least 1.3-fold (0.12 log units) from the limit.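

The change to 2-bromophenyl in place of 4-ethylphenyl on an amide-type nitrogen gives an at least 4.9-fold higher number from compound 1 to compound 4 (0.69 log units; beyond the scatter) in this assay, and this size is only a bound. Compound 4 stands at a limit of the assay and not at a number. A bromo on the phenyl therefore does not bring the number back within the reach of the assay, something compound 2 alone could not show, and the step from compound 2 to compound 4 cannot be read, since both values are limits: the limit of > 4000 nM in this assay, at which 2 of the 4 values shown sit.

From the compounds shown here alone, whether the bromo changes anything at all remains open. So does whether a 4-methoxyphenyl or a 4-aminophenyl on the amide-type nitrogen would fall nearer compound 1 or compound 4.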